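The compounds below may be only part of what the source reports. "The series", "measured", "known", "first", "only" and "open" are said of these compounds alone.

Measured so far:
compound 1 `O=C(/C=C/c1ccc2c(c1)B(O)OC2)c1ccc(F)cc1`, compound 2 `COc1ccc(C(=O)/C=C/c2ccc3c(c2)B(O)OC3)cc1`, compound 3 `CCOC(=O)c1ccc(C(=O)/C=C/c2ccc3c(c2)B(O)OC3)cc1`.

In an ADME assay on L929 cells (Mus musculus) for cytotoxicity, read by resazurin assay, with a stated time of 72 h (a higher number here means a weaker inhibitor, a lower number a stronger inhibitor), compound 1 gives > 10 ug/mL, which is a limit of the assay and not a number. Compound 2 likewise gives a limit, > 10 ug/mL. Compound 3 also gives a limit, > 10 ug/mL. All three values sit at the limit of > 10 ug/mL in this assay, at which 3 of the 3 values shown sit, so the steps a step that the two limits leave unreadable from compound 1 to compound 2, a step that the two limits leave unreadable from compound 1 to compound 3 and a step that the two limits leave unreadable from compound 2 to compound 3 cannot be read. Compound 4 `Nc1cccc(C(=O)/C=C/c2ccc3c(c2)B(O)OC3)c1` differs from compound 1 by 3-aminophenyl in place of 4-fluorophenyl on a carbonyl carbon. The three measured steps each swap one group on an aromatic carbon of the part attached to the carbonyl carbon and all stayed at the limit, so the step expected from this change is estimated as a step that the limit leaves unreadable from compound 1 to compound 4. Compound 4 is therefore expected to give about 15 ug/mL, with a range from 7 ug/mL to 40 ug/mL, most likely reported again as a limit.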

Compound 4, half-maximal inhibitory concentration: 10 ug/mL
For compound 4 the middle estimate is 1.5-fold (0.18 log units) above the measured one; low and high end bracket the measured number.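

In this assay, among these compounds, 3-aminophenyl in place of 4-fluorophenyl on the carbonyl carbon gives the only value at this position that is a number and not a limit, with compound 4 at 10 ug/mL. Among the compounds shown here, the change can be stated only as a number no higher from compound 1 to compound 4 (the limit leaves the size open), and the earlier steps cannot be read at all. The remaining values all stay at one limit: the limit of > 10 ug/mL in this assay, at which 3 of the 4 values shown sit.

The compounds shown do not separate the amine from where it sits, as a 4-aminophenyl group is not among them. Going by these compounds, how a carboxylic acid or an amide at this position would read in this assay also stays open.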